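The source may report more compounds than this note shows. Statements on the series, on what has been measured and on what is new or still open speak of the compounds shown alone.

Three compounds share one core in which a sulfonyl group carries a varied aromatic ring. In a functional assay on HEK293 cells for inhibition of 5-hydroxytryptamine receptor 6 (Homo sapiens), read by calcium flux and cAMP accumulation, with a stated time of 10 min (a higher number here means a weaker inhibitor, a lower number a stronger inhibitor), compound 1 `CN(C)/C=N/N=C/c1cn(S(=O)(=O)c2ccccc2)c2cccc([N+](=O)[O-])c12` gives 1830 nM, compound 2 `COc1ccc(S(=O)(=O)n2cc(/C=N/N=C/N(C)C)c3c([N+](=O)[O-])cccc32)cc1` gives 740 nM, and compound 3 `COc1ccc(OC)c(S(=O)(=O)n2cc(/C=N/N=C/N(C)C)c3c([N+](=O)[O-])cccc32)c1` gives 1400 nM. Compound 3 thus sits between the other two, with a 1.3-fold lower number from compound 1 to compound 3 (0.12 log units; within the scatter) and a 1.9-fold higher number from compound 2 to compound 3 (0.28 log units; within the scatter) both small. Compound 4 `CN(C)/C=N/N=C/c1cn(S(=O)(=O)c2cccc3ccccc23)c2cccc([N+](=O)[O-])c12` differs from compound 3 by naphthalen-1-yl in place of 2,5-dimethoxyphenyl on a sulfonyl sulfur. The two earlier changes at this same sulfonyl sulfur, a 1.3-fold lower number from compound 1 to compound 3 (0.12 log units; within the scatter) and a 1.9-fold higher number from compound 2 to compound 3 (0.28 log units; within the scatter), stayed within the scatter or close to it, so no step beyond the scatter is expected in this assay for compound 4. The expected outcome for compound 4 is therefore 1500 nM, in a range from 500 nM to 4500 nM, meaning an estimated 1.1-fold higher number from compound 3 to compound 4 (0.03 log units; within the scatter).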

Compound 4, half-maximal inhibitory concentration: 2960 nM
Estimate against measurement, compound 4: 2.0-fold (0.30 log units) below, and the stated range covers the measured number.
By their numbers in this assay, from the lowest: compounds 2, 3, 1 and 4 (each within the scatter of the next, the first and the last beyond it).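

In this assay, the sulfonyl sulfur now shows a step beyond the scatter when naphthalen-1-yl replaces a methoxy-bearing ring, whether 2,5-dimethoxyphenyl (a 2.1-fold higher number from compound 3 to compound 4 (0.33 log units; beyond the scatter)) or 4-methoxyphenyl (a 4.0-fold higher number from compound 2 to compound 4 (0.60 log units; beyond the scatter)). Replacing plain phenyl with naphthalen-1-yl stays within the scatter (a 1.6-fold higher number from compound 1 to compound 4 (0.21 log units; within the scatter)). Nothing shown here explains these differences. The compounds shown leave open how a sulfonyl aromatic ring carrying an amine or a carboxylic acid would read. They also leave open what a longer chain in place of the aromatic ring on the sulfonyl sulfur would do.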